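Halogen for Methyl on the Benzyl Ether: Expected Tolerance

A few compounds are considered here, and "the series" means these few. Any claim that something is new, unique, unknown or untested is made for them only; others in the source may bear on it.

In an ADME assay on Huh-5-2 cells (Homo sapiens) for cytotoxicity, read by WST assay, with a stated time of 3 days (a lower number here means that less compound is tolerated, a higher number that more compound is tolerated), the three measured compounds read as follows:
compound 1 `O=c1c(O)c(-c2ccccc2)oc2cc(OCc3ccccc3[N+](=O)[O-])cc(O)c12` gives 32000 nM
compound 2 `O=c1c(O)c(-c2ccccc2)oc2cc(OCc3cccc(Cl)c3)cc(O)c12` reaches only the limit of the assay, > 100000 nM
compound 3 `Cc1cccc(COc2cc(O)c3c(=O)c(O)c(-c4ccccc4)oc3c2)c1` gives 35000 nM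

Compound 3 and compound 1 sit within the scatter of each other, as shown by a 1.1-fold higher number from compound 1 to compound 3 (0.04 log units; within the scatter), while compound 2 shows only a limit, (the limit of > 100000 nM in this assay, at which 1 of the 3 values shown sits). The two steps that reach compound 2 are both beyond the scatter: an at least 3.1-fold higher number from compound 1 to compound 2 (0.49 log units; beyond the scatter) and an at least 2.8-fold lower number from compound 2 to compound 3 (0.45 log units; beyond the scatter), so the 3-chlorophenyl compound is tolerated at higher concentration than either the 2-nitrophenyl or the 3-methylphenyl compound.

Compound 4 `O=c1c(O)c(-c2ccccc2)oc2cc(OCc3ccc(Br)cc3)cc(O)c12` differs from compound 3 by 4-bromophenyl in place of 3-methylphenyl on a saturated chain carbon bound to an oxygen on an aromatic ring. This again puts a halogen on the benzyl ring in place of a methyl, which in the step from compound 3 to compound 2 went with a higher number. Compound 4 is therefore expected to show a higher number, about a 1.7-fold higher number from compound 3 to compound 4 (0.23 log units; within the scatter), giving an estimate of 60000 nM with a range from 25000 nM to 150000 nM in this assay.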

Compound 4, half-maximal cytotoxic concentration: > 100000 nM
Compound 4: only a limit was reported; the forecaster's own chance of this, stated with the estimate: 30%; at least 1.6-fold (0.22 log units) between middle value and limit.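

The change from 3-methylbenzyl to 4-bromobenzyl produces an at least 2.8-fold higher number from compound 3 to compound 4 (0.45 log units; beyond the scatter), and the change from 2-nitrobenzyl to 4-bromobenzyl produces an at least 3.1-fold higher number from compound 1 to compound 4 (0.49 log units; beyond the scatter). In this assay, the higher tolerance seen with the chloro compound therefore also appears with a bromo group at a different place on the ring, and among these four compounds both halogen compounds stand above the methyl and nitro compounds, with none going against this. Compound 2 and compound 4 each reach only a limit, so the step between them cannot be read and chloro cannot be ranked against bromo: the limit of > 100000 nM in this assay, at which 2 of the 4 values shown sit.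

The compounds shown do not separate the kind of halogen from its place on the ring, as 3-bromophenyl and 4-chlorophenyl are absent from this set. They also leave open how a benzyl ring carrying an amine or a carboxylic acid would read.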